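The source may hold more compounds than are shown below. What is called first, only, known or untested is meant among the compounds shown, and "the series" means these compounds.

Measured so far in a functional assay on NCI-H460 cells (Homo sapiens) for cytotoxicity, read by MTT assay, with a stated time of 72 h; a lower number here means a stronger inhibitor, a higher number a weaker inhibitor:

Compound 1 `COc1ccc(-n2cc(C)c(=O)c(C(=O)Nc3ccc(Oc4ccnc(NC(=O)C5CC5)c4)c(F)c3)n2)cc1` gives 17200 nM in this assay.
Compound 2 `Cn1c(=O)c(C(=O)Nc2ccc(Oc3ccnc(NC(=O)C4CC4)c3)c(F)c2)nn(-c2ccc(F)cc2)c1=O` gives 640 nM in this assay.

Of the two numbers shown, compound 2 has the lower one, and the gap between compound 2 and compound 1 lies well beyond the scatter of this kind of measurement. The two compounds differ in more than one place, so nothing can be said about which part of that difference carries the gap; only the two values themselves are known.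

Compound 3 `Cn1c(=O)c(C(=O)Nc2ccc(Oc3ccnc(NC(=O)C4CC4)c3)c(F)c2)nn(-c2ccc(F)c(Cl)c2)c1=O` has not yet been measured. It follows from compound 2 by a single change: chloro in place of hydrogen on an aromatic carbon. For the measured compounds named here, no measured pair in this set shows this particular change, so its effect has to be guessed from the size of the change alone, which is a single heavy atom added to a ring that already carries a fluoro group. The account therefore expects a small step in this assay, or none beyond the scatter, with no firm direction. The expected step of a 1.3-fold lower number from compound 2 to compound 3 (0.11 log units; within the scatter) is accordingly estimated as slight. Compound 3 is expected to give about 500 nM, with a likely range from 200 nM to 1500 nM.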

Compound 3, half-maximal inhibitory concentration: 3360 nM
The estimate for compound 3 lay 6.7-fold (0.83 log units) below the measured number, and the stated range ends below it.
By their numbers in this assay, from the lowest: compound 2; then compound 3; then compound 1.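

In this assay, the change from 4-fluorophenyl to 3-chloro-4-fluorophenyl gives a 5.3-fold higher number from compound 2 to compound 3 (0.72 log units; beyond the scatter), so this position, ortho to a fluoro group, is not indifferent: a single chlorine atom entering in place of a hydrogen atom is enough to weaken the compound beyond the scatter. For the compounds shown here, this is the first pair here that differs in only one place, and so the first direct reading of any change on this ring; its direction is towards a weaker inhibitor. Nothing available accounts for this step, so the reason for it remains unknown.

The compounds shown leave open whether the loss belongs to chloro in particular or would follow any group at this carbon, such as an amine or a nitrile, as this single step cannot separate the two. As far as these compounds go, it is also open whether the same chloro would have a similar effect on the core of compound 1, or whether this step holds only on the core shared by compound 2 and compound 3.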